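Isopropyl for Azetidin-3-yl: Cytotoxicity Expected to Remain Unreadable

The source may hold more compounds than are shown below. What is called first, only, known or untested is meant among the compounds shown, and "the series" means these compounds.

Compound 1 `CS(=O)(=O)CCCn1c(Cn2c(=O)n(C3CC3)c3ccncc32)cc2cc(Cl)ccc21` gives > 50000 nM in an ADME assay on HeLa cells (Homo sapiens) for cytotoxicity, read by ATP content, with a stated time of 3 days (a higher number here means that more compound is tolerated, a lower number that less compound is tolerated), a limit of the assay.
Compound 2 `CS(=O)(=O)CCCn1c(Cn2c(=O)n(CC3CC3)c3ccncc32)cc2cc(Cl)ccc21` gives > 50000 nM, a limit.
Compound 3 `CS(=O)(=O)CCCn1c(Cn2c(=O)n(C3CNC3)c3ccncc32)cc2cc(Cl)ccc21` gives > 50000 nM, a limit.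

Going by the values given here, compound 3 thus stands at the limit of > 50000 nM in this assay, at which 3 of the 3 values shown sit, and no compound here has a number below it. The steps a step that the two limits leave unreadable from compound 1 to compound 2, a step that the two limits leave unreadable from compound 1 to compound 3 and a step that the two limits leave unreadable from compound 2 to compound 3 are all unreadable for the same reason. Compound 4 `CC(C)n1c(=O)n(Cc2cc3cc(Cl)ccc3n2CCCS(C)(=O)=O)c2cnccc21` differs from compound 3 by isopropyl in place of azetidin-3-yl on an aromatic nitrogen. The three measured exchanges on this aromatic nitrogen all left the value at the limit, so no step beyond the scatter is expected from them. Compound 4 is therefore expected to give 60000 nM, within 20000 nM to 150000 nM, most likely again as a limit. The estimated step that the limit leaves unreadable from compound 3 to compound 4 is expected to be without readable size.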

Compound 4, half-maximal cytotoxic concentration: > 50000 nM
Compound 4: no number, only a limit; the forecaster's own chance of this, stated with the estimate: 85%; the middle value lies beyond the limit too.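

Compound 1, compound 2, compound 3 and compound 4 all sit at a limit, so no step among them can be read in this assay: the limit of > 50000 nM in this assay, at which 4 of the 4 values shown sit.

The compounds shown leave open whether these groups on the aromatic nitrogen differ at all in this assay.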